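The source may report more compounds than this note shows. Statements on the series, on what has been measured and on what is new or still open speak of the compounds shown alone.

Of the compounds shown here, three built on one shared core have been tested in a functional assay on HCT-116 cells (Homo sapiens) for antiproliferative activity, with a stated time of 4 h; on this read-out lower numbers stand for stronger inhibition and higher numbers for weaker inhibition. Compound 1 `O=C1NC(=O)c2c1c1c(c3[nH]c4ccccc4c23)C(=O)CCC1` gives 1100 nM. Compound 2 `O=C1CCc2c1c1c(c3c2[nH]c2ccccc23)C(=O)NC1=O` gives 9700 nM. Compound 3 `O=C1NC(=O)c2c1c1c(O)cccc1c1[nH]c3ccccc3c21` gives 17500 nM, the highest of the three numbers; its gap to compound 2 lies within the usual scatter of repeated measurements, while its gap to compound 1 lies well beyond it. Compound 4 `O=C1NC(=O)c2c1c1c(O)ccc(O)c1c1[nH]c3ccccc3c21` has not yet been measured. It differs from compound 3 in one place: hydroxy in place of hydrogen on an aromatic carbon. For the measured compounds named here, no measured pair shows what hydroxy in place of hydrogen does on this core, so the step in this assay can only be estimated. The expected step is a 1.2-fold lower number from compound 3 to compound 4 (0.07 log units; within the scatter), small and of no sure direction. For compound 4 the estimated value is 15000 nM, between 5000 nM and 50000 nM.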

Compound 4, half-maximal inhibitory concentration: 3100 nM
Estimate against measurement, compound 4: 4.8-fold (0.68 log units) above; measured number outside the range, below it.
By their numbers in this assay, from the lowest: compound 1; then compound 4; then compounds 2 and 3 (each within the scatter of the next).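

In this assay, hydroxy in place of hydrogen, on the aromatic carbon para to a hydroxy group, gives a 5.6-fold lower number from compound 3 to compound 4 (0.75 log units; beyond the scatter) on the shared core, so this position responds to substitution and the change is not silent here. This rests on a single pair, so it describes this one place only. No measurement at hand accounts for the step. Open, on these data alone, is whether a methoxy group, an amine or a fluorine on this carbon would lower the number too, and whether hydroxy would act alike on the cores of compound 1 and compound 2.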